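Swapping the aryl group on an alkenyl amide: compound 4

A few compounds are considered here, and "the series" means these few. Any claim that something is new, unique, unknown or untested is made for them only; others in the source may bear on it.

Measured so far, in an assay on isolated protein for displacement of a labelled ligand from melanin-concentrating hormone receptor 1 (Homo sapiens); a lower number here means a stronger inhibitor, a higher number a weaker inhibitor:
compound 1 `CCc1cc(N)c2cc(NC(=O)/C=C/c3ccc(C(F)(F)F)cc3)ccc2n1` gives 1.2 nM;
compound 2 `CCCc1ccc(/C=C/C(=O)Nc2ccc3nc(CCC)cc(N)c3c2)cc1` gives 4 nM;
compound 3 `CC(C)c1cc(N)c2cc(NC(=O)/C=C/c3ccc(C(F)(F)F)cc3)ccc2n1` gives 2.1 nM.

Compound 2 has the highest of the three numbers in this assay. Its nearest neighbour is compound 3, whose value lies within the scatter of that of compound 2, while the gap to compound 1 lies beyond the scatter; compound 1 differs from compound 2 in two places, so only the two values themselves can be compared. Going by the values given here, the one single-point step that is measured, a 1.8-fold higher number from compound 1 to compound 3 (0.24 log units; within the scatter), concerns the saturated chain on the shared core and not the aryl group.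

Compound 4 `CCCc1cc(N)c2cc(NC(=O)/C=C/c3cccc(Cl)c3)ccc2n1` is reached from compound 2 by a change at the other end of the molecule: 3-chlorophenyl in place of 4-propylphenyl on a double-bonded chain carbon bound to a double-bonded chain carbon. Among the compounds with values here, no measured pair changes this aryl group, so the step from compound 2 to compound 4 has no direct precedent; the three values spanning a narrow band suggest a change of modest size. The account therefore expects roughly a 1.3-fold lower number from compound 2 to compound 4 (0.12 log units; within the scatter) in this assay, with a wide range. Compound 4 is estimated at 3 nM, between 0.8 nM and 12 nM.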

Compound 4, half-maximal inhibitory concentration: 1100 nM
Estimate against measurement, compound 4: 370-fold (2.56 log units) below; the whole stated range lies below it.
By their numbers in this assay, from the lowest: compounds 1, 3 and 2 (each within the scatter of the next, the first and the last beyond it); then compound 4.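

In this assay, going by these compounds alone, the aryl group on the double-bonded chain carbon proves a far more sensitive place than the saturated chain on the shared core: 3-chlorophenyl in place of 4-propylphenyl gives a 280-fold higher number from compound 2 to compound 4 (2.44 log units; beyond the scatter) while the only earlier step, a 1.8-fold higher number from compound 1 to compound 3 (0.24 log units; within the scatter) and within the scatter, concerned that chain. Within the data shown here, no earlier pair changed this aryl group, so this is the first sign that the position does not accept every aryl group. Nothing available explains the size of this step.

The change replaces the propyl chain with chlorine and also alters its place on the ring, as the names 4-propylphenyl and 3-chlorophenyl show, and the compounds shown do not separate these two changes. From the compounds shown here alone, how an unsubstituted phenyl group, or a phenyl group carrying a methoxy group or an amine, would read in this assay remains open.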